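A few compounds are considered here, and "the series" means these few. Any claim that something is new, unique, unknown or untested is made for them only; others in the source may bear on it.

All three measured compounds share one core and differ only in the halogen on an aromatic carbon. Compound 1 `CCOC(=O)C1=C(C)N(c2ccc(F)cc2)C=CC1c1ccccc1` gives, in a functional assay, tested at 100 ug/mL (a lower number here means a stronger effect, a higher number a weaker effect of the compound at the concentration tested), a value of -25.7% for compound 1. Compound 2 `CCOC(=O)C1=C(C)N(c2ccc(Cl)cc2)C=CC1c1ccccc1` gives -19.1% in this assay, and compound 3 `CCOC(=O)C1=C(C)N(c2ccc(Br)cc2)C=CC1c1ccccc1` gives -18.7%. The steps between them are small: a number 6.6 percentage points higher from compound 1 to compound 2 (within the scatter), a number 7 percentage points higher from compound 1 to compound 3 (within the scatter) and a number 0.4 percentage points higher from compound 2 to compound 3 (within the scatter). On the numbers shown, compound 2 sits very close to compound 3 and somewhat further from compound 1, yet both gaps lie within the scatter, so the three compounds cannot be told apart in this assay.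

Compound 4 `CC1=C(C(=O)OC(C)(C)C)C(c2ccccc2)C=CN1c1ccc(Cl)cc1` takes a different route from compound 2: tert-butyl in place of ethyl on an oxygen next to a carbonyl group. Within the data shown here, none of the measured steps touches this part of the molecule; all of them swap one halogen for another, and each stayed within the scatter. There is therefore no measured guide for the size or direction of this step, and the plain expectation is a number close to that of compound 2, with no step beyond the scatter in either direction.

For compound 4 the estimated value in this assay is -19%, expected to lie between -35% and -3%. This estimate means an expected step of a number 0.1 percentage points higher from compound 2 to compound 4 (within the scatter).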

Compound 4, a percentage reported as activity, at one concentration (the size of the read-out at that concentration, not a potency): -24.5%
For compound 4 the middle estimate is 5.5 percentage points above the measured one; measured number inside the range.
By their numbers in this assay, from the lowest: compounds 1, 4, 2 and 3 (each within the scatter of the next).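

Compound 4 brings the first change away from the halogen, and it shows that the ester can carry a bulkier alkyl group without a readable shift in this assay. Going from ethyl, with 2 heavy atoms, to tert-butyl, with 4 heavy atoms, on an oxygen next to a carbonyl group gives a number 5.4 percentage points lower from compound 2 to compound 4 (within the scatter) and so leaves compound 4 indistinguishable from compound 2 in this read-out. No measured property of these groups accompanies this result, so the data offer no explanation for it.

On these data alone, this reading rests on a single pair carrying the chloro group, so it remains open whether tert-butyl in place of ethyl would behave the same way alongside the fluoro or bromo group. The compounds shown also give no guide to how a different kind of group at this place would behave, such as a carboxylic acid or an amide in place of the ester, or an ester with a longer chain such as octyl.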